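The source may report more compounds than this note shows. Statements on the series, on what has been measured and on what is new or still open speak of the compounds shown alone.

Of the compounds shown here, three built on one shared core have been measured in an ADME assay on MCF-10A cells (Homo sapiens) for cytotoxicity, read by sulforhodamine B assay, with a stated time of 48 h; on this read-out lower numbers stand for stronger inhibition of growth and higher numbers for weaker inhibition of growth. Compound 1 (`NC(=S)N/N=C1/C(=O)N(CN2CCN(c3ccnc4cc(Cl)ccc34)CC2)c2cc(Cl)ccc21`) gives 64600 nM. Compound 2 (`NC(=S)N/N=C1/C(=O)N(CN2CCN(c3ccnc4cc(Cl)ccc34)CC2)c2cc(Br)ccc21`) gives 22100 nM, and compound 3 (`NC(=S)N/N=C1/C(=O)N(CN2CCN(c3ccnc4cc(C(F)(F)F)ccc34)CC2)c2cc(Cl)ccc21`) gives 38800 nM. The number for compound 3 falls between the other two, but its separation from compound 1 and its separation from compound 2 both stay within the scatter, so no ranking of these three can be drawn from it.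

Compound 4 (`NC(=S)N/N=C1/C(=O)N(CN2CCN(c3ccnc4cc(C(F)(F)F)ccc34)CC2)c2cc(Br)ccc21`) is one step away from compound 3: bromo in place of chloro on an aromatic carbon. This exact exchange has already been made once within the set, in going from compound 1 to compound 2, where it gave a 2.9-fold lower number from compound 1 to compound 2 (0.47 log units; beyond the scatter). Among the measured compounds shown here, the only other measured step, a 1.7-fold lower number from compound 1 to compound 3 (0.22 log units; within the scatter), is a different exchange and does not bear on the present one. For the measured compounds named here, on the strength of the single matching precedent, the exchange is expected to lower the number for compound 4 in this assay by a modest amount, beyond the scatter but not far beyond it. Compound 4 is accordingly estimated at 14000 nM, with a likely range from 7000 nM to 30000 nM. That estimate corresponds to an expected step of a 2.8-fold lower number from compound 3 to compound 4 (0.44 log units; beyond the scatter).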

Compound 4, concentration for 50% growth inhibition: 27000 nM
Beside the measured number, compound 4's estimate is 1.9-fold (0.29 log units) below it; the range from low to high includes it.
By their numbers in this assay, from the lowest: compounds 2, 4, 3 and 1 (each within the scatter of the next, the first and the last beyond it).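

In this assay, the bromo for chloro exchange, on an aromatic carbon para to a fused ring, has now been read a second time, with trifluoromethyl in place of chloro elsewhere in the molecule, and it gives a 1.4-fold lower number from compound 3 to compound 4 (0.16 log units; within the scatter), so the step that lay beyond the scatter on its first reading does not do so here, yet the two readings do not truly disagree: the same change on two cores in this assay, a 2.9-fold lower number (0.47 log units; beyond the scatter) from compound 1 to compound 2 and a 1.4-fold lower number (0.16 log units; within the scatter) from compound 3 to compound 4, 2.0-fold (0.31 log units) apart, within the scatter of two such steps. The trifluoromethyl for chloro exchange can also now be read twice, and with bromo already present it gives a 1.2-fold higher number from compound 2 to compound 4 (0.09 log units; within the scatter), so neither of its two readings leaves the scatter: the same change on two cores in this assay, a 1.7-fold lower number (0.22 log units; within the scatter) from compound 1 to compound 3 and a 1.2-fold higher number (0.09 log units; within the scatter) from compound 2 to compound 4, 2.0-fold (0.31 log units) apart, within the scatter of two such steps. Across the four compounds, therefore, only the two ends of the series are separated beyond the scatter, and the bromo step cannot be given one firm size.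

Two pairs cannot settle whether the size of the bromo step truly depends on the group it is paired with. Also open, on these data alone, is whether an amine or a carboxylic acid in place of the halogen at this position would shift the number beyond the scatter.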